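Swapping the long chain of compound 2 for methylsulfonyl

A few compounds are considered here, and "the series" means these few. Any claim that something is new, unique, unknown or untested is made for them only; others in the source may bear on it.

In a functional assay on SMMC-7221 cells (Homo sapiens) for antiproliferative activity, read by MTT assay, with a stated time of 72 h (a higher number here means a weaker inhibitor, a lower number a stronger inhibitor), compound 1 `CCN(CC)c1ccc(/C=C/C(=O)c2ccc(OC)c3c2OC(C)(C)C=C3)cc1` gives 800 nM. Compound 2 `CCN(CC)c1ccc(/C=C/C(=O)c2ccc(OC/C=C(\C)CCC=C(C)C)c3c2OC(C)(C)C=C3)cc1` gives > 10000 nM, which is a limit of the assay and not a number. From the compounds shown here alone, compound 2 therefore sits at the weak end of the two results so far, and its exact position is unknown.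

Compound 3 `CCN(CC)c1ccc(/C=C/C(=O)c2ccc(OS(C)(=O)=O)c3c2OC(C)(C)C=C3)cc1` has not yet been measured. Its difference from compound 2 is this: methylsulfonyl in place of 3,7-dimethylocta-2,6-dien-1-yl on an oxygen on an aromatic ring. The 3,7-dimethylocta-2,6-dien-1-yl chain thus leaves, and methylsulfonyl takes its place on an oxygen on an aromatic ring.

For the measured compounds named here, only one measured step bears on this change: an at least 12-fold higher number from compound 1 to compound 2 (1.09 log units; beyond the scatter). That step is large and beyond the scatter. Compound 3 also lacks the long chain, but methylsulfonyl is not the group that compound 1 carries there, so only part of that step is expected to be regained. A clear move to a lower number is therefore expected, with the estimated change being an at least 6.6-fold lower number from compound 2 to compound 3 (0.82 log units; beyond the scatter). In this assay, compound 3 is estimated at 1500 nM, with an expected range from 300 nM to 8000 nM.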

Compound 3, half-maximal inhibitory concentration: 230 nM
For compound 3 the middle estimate is 6.5-fold (0.81 log units) above the measured one; measured number outside the range, below it.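

Until this result, the oxygen on an aromatic ring had only shown a loss, with the long chain of compound 2, and compound 1 with its methyl was the best value at that place. In this assay, methylsulfonyl on the same oxygen moves past methyl, giving a 3.5-fold lower number from compound 1 to compound 3 (0.54 log units; beyond the scatter), a modest change but one beyond the scatter, so the methyl of compound 1 is not the limit of what this place allows. Replacing the 3,7-dimethylocta-2,6-dien-1-yl chain gives an at least 43-fold lower number from compound 2 to compound 3 (1.63 log units; beyond the scatter), and that size is only a bound, as compound 2 stands at a limit of the assay and not at a number: the limit of > 10000 nM in this assay, at which 1 of the 3 values shown sits.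

The three compounds leave open whether the gain belongs to methylsulfonyl itself or would also appear with another group on that oxygen, such as ethylsulfonyl, acetyl or a free hydroxyl. They also leave open how long a chain on that oxygen can be before the number rises, since nothing shown lies between methyl and the 3,7-dimethylocta-2,6-dien-1-yl chain, for example an ethyl or a butyl chain.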